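This account rests on a few compounds, and the source may have more. Where it says the series, first, only, none or still open, it means among the compounds named here.

Among the compounds with values here, in a functional assay on A549 cells (Homo sapiens) for antiproliferative activity, read by MTT assay (a higher number here means a weaker inhibitor, a lower number a stronger inhibitor), compound 1 `Cc1c(-n2cc(COc3ccc(/C=C/C(=O)c4cc5c(cc4O)OC(C)(C)CC5)cc3)nn2)cccc1[N+](=O)[O-]` gives 65900 nM as the lowest of the two numbers so far, and compound 2 `CC(=O)c1ccc(-n2cc(COc3ccc(/C=C/C(=O)c4ccc5c(c4O)CCC(C)(C)O5)cc3)nn2)cc1` gives 149000 nM at a gap beyond the scatter. Compound 3 `CC1(C)CCc2cc(C(=O)/C=C/c3ccc(OCc4cn(Cc5ccc([N+](=O)[O-])cc5)nn4)cc3)c(O)cc2O1` keeps the core of compound 1 and carries 4-nitrobenzyl in place of 2-methyl-3-nitrophenyl on an aromatic nitrogen. Within the data shown here, no measured pair shows this change, so neither direction is favoured. In this assay no step beyond the scatter is expected (a 1.1-fold lower number from compound 1 to compound 3 (0.04 log units; within the scatter)). The expected value for compound 3 is 60000 nM with an estimated range from 20000 nM to 170000 nM for now.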

Compound 3, half-maximal inhibitory concentration: 35800 nM
Estimate against measurement, compound 3: 1.7-fold (0.22 log units) above; low and high end bracket the measured number.
By their numbers in this assay, from the lowest: compounds 3 and 1 (each within the scatter of the next); then compound 2.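

Read in this assay the change to 4-nitrobenzyl from 2-methyl-3-nitrophenyl on the aromatic nitrogen gives a 1.8-fold lower number from compound 1 to compound 3 (0.27 log units; within the scatter) and so does not separate the two groups. Within the data shown here, this position therefore accepts either group in this read-out, although the single step changes both the ring attachment and the nitro placement and cannot divide them. Nothing on hand gives a cause for this result. Open, from the compounds shown here alone, is whether an amine or a carboxylic acid in place of the nitro group, or a longer chain in place of the benzyl link, would give a step beyond the scatter.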